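Aryl variation at the saturated ring carbon of the shared core

The compounds below may be only part of what the source reports. "The series", "measured", "known", "first", "only" and "open" are said of these compounds alone.

Measured compounds:
- compound 1 `COc1cc(N2C(N)=C(C#N)C(c3ccc(OC)c4ccccc34)C3=C2CC(C)(C)CC3=O)cc(OC)c1OC`: 40%
- compound 2 `COc1cc(N2C(N)=C(C#N)C(c3c(O)ccc4ccccc34)C3=C2CC(C)(C)CC3=O)cc(OC)c1OC`: 15%
- compound 3 `COc1cc(N2C(N)=C(C#N)C(c3ccc(Cl)cc3Cl)C3=C2CC(C)(C)CC3=O)cc(OC)c1OC`: 95%

In a functional assay on Ehrlich cells (Mus musculus) for cytotoxicity, tested at 50 ug/mL (a lower number here means a weaker effect, a higher number a stronger effect of the compound at the concentration tested), compound 3 gives the highest of the three numbers; the nearest is compound 1, the furthest compound 2, and both of those gaps lie beyond the scatter. The two steps that lead into compound 3 are large: a number 55 percentage points higher from compound 1 to compound 3 (beyond the scatter) and a number 80 percentage points higher from compound 2 to compound 3 (beyond the scatter). The step between the two naphthyl-bearing compounds is smaller, a number 25 percentage points lower from compound 1 to compound 2 (beyond the scatter).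

Compound 4 `COc1cc(N2C(N)=C(C#N)C(c3cccs3)C3=C2CC(C)(C)CC3=O)cc(OC)c1OC` is not yet measured. It differs from compound 3 in one place: thiophen-2-yl in place of 2,4-dichlorophenyl on a saturated ring carbon. Among the compounds with values here, no measured step replaces the 2,4-dichlorophenyl group with a five-membered heteroaryl, so nothing here speaks directly to this change. What the series does show is that the 2,4-dichlorophenyl group stands apart from the other aryl groups at this position, with large gains over both compound 1 and compound 2. On that basis compound 4 is expected to fall back toward the level of compound 1 in this assay, though the size of that fall is uncertain. The expected step in this assay is estimated as a number 50 percentage points lower from compound 3 to compound 4 (beyond the scatter). The estimate for compound 4 in this assay is 45%, with a range from 15% to 85%.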

Compound 4, a percentage reported as activity, at one concentration (the size of the read-out at that concentration, not a potency): 15%
Compound 4: middle estimate off by 30 percentage points, on the high side, and the stated range covers the measured number.
By their numbers in this assay, from the lowest: compounds 2 and 4 (each within the scatter of the next); then compound 1; then compound 3.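

In this assay, the 2,4-dichlorophenyl result does not carry over to a smaller aromatic ring at the saturated ring carbon: replacing it with thiophen-2-yl gives a number 80 percentage points lower from compound 3 to compound 4 (beyond the scatter), so the high number in this series still belongs to compound 3 alone. Thiophen-2-yl also gives a number 25 percentage points lower from compound 1 to compound 4 (beyond the scatter) and no change at the digits printed from compound 2 to compound 4 (within the scatter), which places compound 4 level with compound 2 and shows that a five-membered aromatic ring with 1 hetero atom and a 2-hydroxynaphthalen-1-yl group, despite their different sizes, cannot be told apart in this assay. Nothing available explains the separation of the 2,4-dichlorophenyl group from the other three groups.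

Still open, as far as these compounds go, is whether the high number depends on the two chlorine atoms or on the six-membered aromatic ring that carries them, a question that a phenyl group without chlorine and a 4-chlorophenyl group at this carbon would address. A 5-chlorothiophen-2-yl group would further show whether chlorine on the five-membered ring recovers any of the number lost in compound 4.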